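The compounds below may be only part of what the source reports. "The series", "measured", "known", "first", "only" and "open" are said of these compounds alone.

Measured so far in a functional assay on HL-60 cells (Homo sapiens) for antiproliferative activity, read by XTT assay, with a stated time of 72 h; on this read-out higher numbers stand for weaker inhibition and lower numbers for stronger inhibition (every value here is a limit of the assay):
- compound 1 `Cc1nc(N)c2c(-c3ccco3)cn([C@@H]3O[C@H](CO)[C@@H](O)[C@H]3O)c2n1` gives > 20000 nM as a limit
- compound 2 `Cc1nc(N)c2c(-c3ccoc3)cn([C@@H]3O[C@H](CO)[C@@H](O)[C@H]3O)c2n1` gives > 20000 nM as a limit
- compound 3 `Cc1nc(N)c2c(-c3cc4ccccc4o3)cn([C@@H]3O[C@H](CO)[C@@H](O)[C@H]3O)c2n1` gives > 20000 nM as a limit

Compound 3 stands at > 20000 nM as a limit and not as a number. The same holds for the whole set (the limit of > 20000 nM in this assay, at which 3 of the 3 values shown sit). Compound 4 `Cc1nc(N)c2c(I)cn([C@@H]3O[C@H](CO)[C@@H](O)[C@H]3O)c2n1` carries iodo in place of 1-benzofuran-2-yl on an aromatic carbon and keeps the rest of the core.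

The measured steps give little help. They are a step that the two limits leave unreadable from compound 1 to compound 2 and a step that the two limits leave unreadable from compound 1 to compound 3 and also a step that the two limits leave unreadable from compound 2 to compound 3 as the third. Each swaps one ring group for another, and none yields a size. Iodo is a change of another kind, so no step size can be carried over.

The expectation therefore starts from compound 3 at > 20000 nM as a limit: compound 4 is expected to stay near it, with some room toward stronger inhibition in this assay and a good chance of another limit. The estimated change is an at least 1.3-fold lower number from compound 3 to compound 4 (0.12 log units; that floor lies within the scatter) and no firmer than that. For compound 4 the expected value is 15000 nM with an estimated range of 2500 nM to 40000 nM as the likely span.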

Compound 4, half-maximal inhibitory concentration: 2050 nM
Beside the measured number, compound 4's estimate is 7.3-fold (0.86 log units) above it; the measured number lies below the stated range.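

In this assay, the aromatic carbon two ring bonds from the ring nitrogen can carry a group that gives a readable number: replacing a ring group with iodo gives an at least 9.7-fold lower number from compound 3 to compound 4 (0.98 log units; beyond the scatter), and likewise an at least 9.7-fold lower number from compound 2 to compound 4 (0.98 log units; beyond the scatter) and an at least 9.7-fold lower number from compound 1 to compound 4 (0.98 log units; beyond the scatter). The earlier compounds shown here differ from one another only by steps that cannot be read, so they could not show whether this position responds to what it carries, whereas the single iodine atom shows that it does. The full size of these steps stays hidden, since each starts from a limit and not from a number: the limit of > 20000 nM in this assay, at which 3 of the 4 values shown sit.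

Going by these compounds, it remains open whether the gain belongs to iodine itself or simply to the loss of a ring group, a question that chloro, bromo, methyl or an amine at the same carbon would bear on. Among these compounds, with only one readable value in the set, how the three ring groups rank among themselves and how much further the number could fall also remain open.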